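The source may report more compounds than this note shows. Statements on the series, on what has been measured and on what is new or still open speak of the compounds shown alone.

Working notes on the series. Among the measured compounds shown here, compound 3 `O=C(/C=C/c1cccs1)Nc1ccc2ncnc(Nc3cccc(Cl)c3)c2c1` is the anilide with a thiophen-2-yl ethenyl carbonyl on the ring nitrogen; in a functional assay on HepG2 cells (Homo sapiens) for antiproliferative activity, read by MTT assay, with a stated time of 48 h (a lower number here means a stronger inhibitor, a higher number a weaker inhibitor), compound 3 gives 10400 nM, the highest number of the three measured so far. Compound 2 `O=C(/C=C/c1cccnc1)Nc1ccc2ncnc(Nc3cccc(Cl)c3)c2c1` carries pyridin-3-yl in the same place and in this assay compound 2 gives 9120 nM; the step of a 1.1-fold higher number from compound 2 to compound 3 (0.06 log units; within the scatter) is small. Compound 1 `Cc1cccc(CNc2ccc3ncnc(Nc4cccc(Cl)c4)c3c2)n1` has instead a (6-methylpyridin-2-yl)methyl group on that nitrogen, and in this assay compound 1 gives 3630 nM, the step being a 2.9-fold higher number from compound 1 to compound 3 (0.46 log units; beyond the scatter).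

Compound 4 `Cc1cccc(/C=C/C(=O)Nc2ccc3ncnc(Nc4cccc(Cl)c4)c3c2)n1` is the next variation: 6-methylpyridin-2-yl in place of thiophen-2-yl on a double-bonded chain carbon bound to a double-bonded chain carbon. The step from compound 2 to compound 3 shows that swapping one aromatic ring for another on the ethenyl chain barely moved the number, while compound 1 shows the 6-methylpyridin-2-yl ring at a lower number in a different linkage. A step of a 1.5-fold lower number from compound 3 to compound 4 (0.17 log units; within the scatter) is therefore expected, modest and downward if anything. Compound 4 is estimated at 7000 nM, within 3000 nM to 16000 nM.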

Compound 4, half-maximal inhibitory concentration: 4820 nM
Compound 4: the middle estimate sits 1.5-fold (0.16 log units) above what was measured, within the range that was stated.
By their numbers in this assay, from the lowest: compounds 1, 4, 2 and 3 (each within the scatter of the next, the first and the last beyond it).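

Among the compounds shown here, on a double-bonded chain carbon bound to a double-bonded chain carbon, the aromatic rings are not fully interchangeable: in this assay, 6-methylpyridin-2-yl gives a 2.2-fold lower number from compound 3 to compound 4 (0.33 log units; beyond the scatter), the first step at this place to lie beyond the scatter. The gain is modest and holds only against thiophen-2-yl, since the same ring in place of pyridin-3-yl gives a 1.9-fold lower number from compound 2 to compound 4 (0.28 log units; within the scatter), which stays within the scatter. Nothing at hand gives a reason for the step.

The compounds shown do not separate the contribution of the methyl group from that of the pyridin-2-yl ring itself, which an unsubstituted pyridin-2-yl would address. As far as these compounds go, whether a phenyl ring, or a dimethylamino group on the chain, would hold the number at this level remains open.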